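The source may hold more compounds than are shown below. What is called first, only, known or untested is meant among the compounds shown, and "the series" means these compounds.

In a functional assay on LOX IMVI cells (Homo sapiens) for inhibition, read by sulforhodamine B assay, with a stated time of 48 h, tested at 10 uM (a higher number here means more inhibition at the concentration tested (going by the name of the read-out), a lower number less inhibition), compound 1 `Brc1cn2ccnc2c(-c2ccc3ncn(C4CCCCC4)c3c2)n1` gives 15.2% and stands highest of the three numbers measured. Compound 2 `c1ccc2c(-c3cn4ccnc4c(-c4ccc5ncn(C6CCCCC6)c5c4)n3)cccc2c1` gives 7.43% in this assay, and compound 3 `c1cn2cc(-c3ccsc3)nc(-c3ccc4ncn(C5CCCCC5)c4c3)c2n1` gives 4.9%. The step of a number 7.8 percentage points lower from compound 1 to compound 2 (within the scatter) stays within the scatter, whereas the step of a number 10.3 percentage points lower from compound 1 to compound 3 (beyond the scatter) lies beyond it, though only modestly; between compounds 2 and 3 the step of a number 2.5 percentage points lower from compound 2 to compound 3 (within the scatter) is within the scatter.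

Compound 4 `FC(F)(F)c1cccc(-c2cn3ccnc3c(-c3ccc4ncn(C5CCCCC5)c4c3)n2)c1` arises from compound 1 by the change (3-(trifluoromethyl)phenyl in place of bromo on an aromatic carbon). For the measured compounds named here, both measured steps that bear on it, the one from compound 1 to compound 2 and the one from compound 1 to compound 3, put an aromatic ring on the same carbon in place of bromo and each gave a lower number, one within and one just beyond the scatter. A step of similar size and direction is therefore expected in this assay, which means an estimated change of a number 8.2 percentage points lower from compound 1 to compound 4 (within the scatter). On that basis compound 4 is expected to give about 7% in this assay, within a range from -5% to 19%.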

Compound 4, a percentage reported as inhibition, at one concentration (the size of the read-out at that concentration, not a potency): 3.45%
Beside the measured number, compound 4's estimate is 3.6 percentage points above it; the range from low to high includes it.
By their numbers in this assay, from the lowest: compounds 4, 3, 2 and 1 (each within the scatter of the next, the first and the last beyond it).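

Replacing bromo on the aromatic carbon next to the ring nitrogen with 3-(trifluoromethyl)phenyl in this assay gives a number 11.8 percentage points lower from compound 1 to compound 4 (beyond the scatter) and so adds a second aromatic replacement whose step from bromo lies beyond the scatter, while the naphthalen-1-yl step stays within it. The choice among these aromatic groups cannot be read here, since the data show a number 1.5 percentage points lower from compound 3 to compound 4 (within the scatter) and a number 4 percentage points lower from compound 2 to compound 4 (within the scatter) and neither step leaves the scatter. Nothing available accounts for the position of bromo relative to the aromatic groups.

From the compounds shown here alone, it remains open whether an amine, a carboxylic acid or a short alkyl chain on this carbon would fall with bromo or with the aromatic groups. Also open, going by these compounds, is how chloro would compare with bromo, and whether changes elsewhere on the shared core would alter these steps.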